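The source may report more compounds than this note shows. Statements on the series, on what has been measured and on what is new or still open speak of the compounds shown alone.

Of the compounds shown here, three of a shared core have been measured for their ability to block the prostaglandin E2 receptor EP1 subtype. Compound 1 `Cc1cc(C(=O)O)nn1Cc1cc(Br)ccc1OCc1ccc(Cl)cc1` gives 8.71 nM in a functional assay on CHO-K1 cells for antagonist activity at prostaglandin E2 receptor EP1 subtype (Homo sapiens), read by FLIPR; a lower number here means a stronger inhibitor, a higher number a weaker inhibitor. Compound 2 `Cc1cc(C(=O)O)nn1Cc1cc(Br)ccc1OCc1ccc(F)cc1` gives 11.8 nM in this assay, and the step of a 1.4-fold higher number from compound 1 to compound 2 (0.13 log units; within the scatter) lies within the scatter. Compound 3 `Cc1cc(C(=O)O)nn1Cc1cc(Br)ccc1OCc1ccc(C(F)(F)F)cc1` gives 97.7 nM in this assay, the highest of the three numbers: the step of an 11-fold higher number from compound 1 to compound 3 (1.05 log units; beyond the scatter) and the step of an 8.3-fold higher number from compound 2 to compound 3 (0.92 log units; beyond the scatter) both carry it well clear of the two halogen-bearing compounds.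

Compound 4 `Cc1cc(C(=O)O)nn1Cc1cc(Br)ccc1OCc1ccc(C(C)(C)C)cc1` differs from compound 3 in one place: tert-butyl in place of trifluoromethyl on an aromatic carbon. Within the data shown here, no measured step pairs a trifluoromethyl group with a tert-butyl group at this position. The two steps that do bear on the position show that replacing a chlorine or a fluorine by trifluoromethyl raised the number by a wide margin, so that the two halogens stand far below compound 3. Among the measured compounds shown here, a tert-butyl group is a further departure from those halogens, and no measured compound suggests the number should fall back toward compound 1 or compound 2.

Compound 4 is therefore expected to give about 150 nM in this assay, with a likely range from 40 nM to 600 nM. The estimate implies a step of a 1.5-fold higher number from compound 3 to compound 4 (0.19 log units; within the scatter), expected to stay near compound 3 rather than recover the potency of the halogen-bearing compounds.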

Compound 4, inhibition constant: < 2000 nM
Compound 4: only a limit was reported; the forecaster's own chance of this, stated with the estimate: 5%; the middle value lies beyond the limit too.
By their numbers in this assay, from the lowest: compounds 1 and 2 (each within the scatter of the next); then compound 3.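

In this assay compound 4 gives < 2000 nM as its result, which is a limit and not a number. Among these compounds, no new step can therefore be read: the steps from compound 1, compound 2 and compound 3 to compound 4 all stay unreadable. The compounds shown leave open where compound 4, with its tert-butyl group, stands relative to the other three.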